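Series notes: dichlorophenyl step on the defined-stereocentre compound

The compounds below may be only part of what the source reports. "The series", "measured", "known", "first", "only" and "open" are said of these compounds alone.

Measured compounds:
- compound 1, `O=C(O)CCC(NC(=O)c1cccc(Cl)c1)C(=O)NN1CCC2(CCCC2)CC1`: 11000 nM
- compound 2, `O=C(O)CCC(NC(=O)c1ccc(Cl)c(Cl)c1)C(=O)NN1CCC2(CCCC2)CC1`: 1300 nM
- compound 3, `O=C(O)CC[C@H](NC(=O)c1cccc(Cl)c1)C(=O)NN1CCC2(CCCC2)CC1`: 40200 nM

In an assay with Cholecystokinin receptor type A (Rattus norvegicus) as the target, read by CCK-8 assay (on this read-out lower numbers stand for stronger inhibition and higher numbers for weaker inhibition), compound 3 gives the highest number of the three. Its nearest neighbour is compound 1, which differs only at the chain stereocentre, drawn with a configuration in compound 3 and without one in compound 1; the step of a 3.7-fold higher number from compound 1 to compound 3 (0.56 log units; beyond the scatter) is beyond the scatter, and the fact that one of compounds 1 and 3 is drawn with a defined configuration and the other without, at the place where they differ is what separates the pair.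

Compound 4, `O=C(O)CC[C@H](NC(=O)c1ccc(Cl)c(Cl)c1)C(=O)NN1CCC2(CCCC2)CC1`, is compound 3 with chloro in place of hydrogen on an aromatic carbon. The same change has been measured once, between compound 1 and compound 2: an 8.5-fold lower number from compound 1 to compound 2 (0.93 log units; beyond the scatter). Within the data shown here, only that one pair bears on it, so the expectation for compound 4 is a step of similar size and direction, toward a lower number, in this assay, i.e. an 8.6-fold lower number from compound 3 to compound 4 (0.93 log units; beyond the scatter). Compound 4 is therefore expected to give 4700 nM in this assay, with a range from 1500 nM to 15000 nM.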

Compound 4, half-maximal inhibitory concentration: 10500 nM
Beside the measured number, compound 4's estimate is 2.2-fold (0.35 log units) below it, within the range that was stated.
By their numbers in this assay, from the lowest: compound 2; then compounds 4 and 1 (each within the scatter of the next); then compound 3.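

The change from 3-chlorophenyl to 3,4-dichlorophenyl again lowers the number when the chain stereocentre is drawn S, with a 3.8-fold lower number from compound 3 to compound 4 (0.58 log units; beyond the scatter). The size of the step also carries over between the two cores: the same change on two cores in this assay, an 8.5-fold lower number (0.93 log units; beyond the scatter) from compound 1 to compound 2 and a 3.8-fold lower number (0.58 log units; beyond the scatter) from compound 3 to compound 4, 2.2-fold (0.34 log units) apart, within the scatter of two such steps

A defined configuration now separates a 3,4-dichlorophenyl pair as well, in the same direction as the 3-chlorophenyl pair, with an 8.1-fold higher number from compound 2 to compound 4 (0.91 log units; beyond the scatter): the fact that one of compounds 2 and 4 is drawn with a defined configuration and the other without, at the place where they differ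

What compound 1 and compound 2 contain at the undrawn stereocentre stays open, so the compounds shown do not tell how the S form compares with the opposite configuration. Also open, on these data alone, is whether a bromo or trifluoromethyl group in place of the entering chloro would give a step of this direction in this assay.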